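Acyl chain extension on the aminophenyl thiadiazoline series

The source may report more compounds than this note shows. Statements on the series, on what has been measured and on what is new or still open speak of the compounds shown alone.

Measured so far:
compound 1 `CC1(C)SC(c2ccccc2N)=NN1C(=O)c1ccccc1`: 39.8%
compound 2 `CCCCC(=O)N1N=C(c2cc(Cl)ccc2N)SC1(C)C`: 12.6%
compound 3 `CCC(=O)N1N=C(c2ccccc2N)SC1(C)C`: 19.2%

In an assay on isolated protein for inhibition of Nitric oxide synthase, inducible (Homo sapiens), read by scintillation counting, with a stated time of 30 min, tested at 50 uM (on this read-out higher numbers stand for more inhibition at the one concentration tested (going by the name of the read-out) and lower numbers for less inhibition), compound 1 gives 39.8%, compound 2 gives 12.6% and compound 3 gives 19.2%. Compound 3 stands below compound 1 by a margin beyond the scatter, and within the scatter of compound 2; no order between compound 2 and compound 3 can be read from these two numbers.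

For the measured compounds named here, the one clean step measured so far is a number 20.6 percentage points lower from compound 1 to compound 3 (beyond the scatter), so replacing the phenyl on the carbonyl carbon by a short saturated chain cost a modest amount of inhibition.

Compound 4 `CCCCC(=O)N1N=C(c2ccccc2N)SC1(C)C` is not yet measured. It differs from compound 3 by ethyl in place of hydrogen on a saturated chain carbon, two bonds along the chain from a carbonyl carbon. Going by the values given here, no measured pair isolates this change: compound 2 carries the same butylcarbonyl group but also a chloro substituent, so its value against compound 3 reflects two changes at once. Still, compound 2 at 12.6% gives no sign that the longer chain raises inhibition, and the step from compound 1 to compound 3 argues that the acyl group matters.

The expected step is therefore small, a number 4.2 percentage points lower from compound 3 to compound 4 (within the scatter), not beyond the scatter. Compound 4 is estimated at 15%, expected between 4% and 28%.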

Compound 4, a percentage reported as inhibition, at one concentration (the size of the read-out at that concentration, not a potency): 39.1%
The estimate for compound 4 lay 24.1 percentage points below the measured number, outside the stated range (above it).
By their numbers in this assay, from the lowest: compounds 2 and 3 (each within the scatter of the next); then compounds 4 and 1 (each within the scatter of the next).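

In this assay, for the compounds shown here, the saturated chain position two bonds along the chain from a carbonyl carbon proves responsive: ethyl in place of hydrogen gives a number 19.9 percentage points higher from compound 3 to compound 4 (beyond the scatter), a change that no earlier pair isolated. Phenyl on the carbonyl carbon also no longer stands out, since butyl in its place gives a number 0.7 percentage points lower from compound 1 to compound 4 (within the scatter), so the drop seen in a number 20.6 percentage points lower from compound 1 to compound 3 (beyond the scatter) is tied to the ethyl compound and not to every replacement of phenyl. The low number of compound 2 now reads differently as well: hydrogen in place of chloro on an aromatic carbon gives a number 26.5 percentage points higher from compound 2 to compound 4 (beyond the scatter), which ties that number to the chloro and not to the butylcarbonyl chain, though nothing on hand explains any of these steps.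

On these data alone, whether a longer chain than butyl raises the number further or levels off remains open, as does the effect of an amine or a carboxylic acid at the end of the chain. Also open, as far as these compounds go, is whether fluoro or methoxy in place of the chloro on that aromatic carbon would bring a similar drop.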